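The compounds below may be only part of what the source reports. "The series", "measured", "known", "first", "only" and "open" are said of these compounds alone.

Measured so far:

compound 1 `CC[C@@H](Nc1c(C#N)c(-c2ccc(-c3ncccc3C)cc2)nc2cnccc12)C(N)=O` — 2
compound 2 `CC[C@H](Nc1c(C#N)c(-c2ccc(Br)cc2)nc2cnccc12)C(N)=O` — 2.3
compound 3 `CC[C@@H](Nc1c(C#N)c(-c2ccc(Br)cc2)nc2cnccc12)C(=O)O` — 1.6

Working notes on the series. In a physicochemical assay for lipophilicity, read by HPLC, at pH 7.5 (a lower number here means a more polar compound, a higher number a more lipophilic compound), compound 1 gives 2, the second highest of the three numbers; its nearest neighbour is compound 2, whose value lies within the scatter of it, and the furthest is compound 3, whose value lies beyond the scatter below it. Going by the values given here, the only step between two measured compounds that differ in one place is a number 0.70 log units lower from compound 2 to compound 3 (beyond the scatter), with 1-carboxypropyl in place of 1-carbamoylpropyl on a nitrogen on an aromatic ring.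

The next compound, compound 4 `CC[C@@H](Nc1c(C#N)c(-c2ccc(Br)cc2)nc2cnccc12)C(N)=O`, is to be measured in this assay. It differs from compound 1 as follows: bromo in place of 3-methylpyridin-2-yl on an aromatic carbon. Among the compounds with values here, no measured step bears on this change, since the one step known alters the group on the ring nitrogen and leaves the bromo-bearing ring untouched. What the values do show is that compound 2, which carries bromo at that place and 1-carbamoylpropyl on the ring nitrogen, gives 2.3 in this assay, within the scatter of compound 1. On that basis the expected step of a number 0.30 log units higher from compound 1 to compound 4 (within the scatter) is small and within the scatter. Compound 4 is therefore estimated at 2.3, with a range from 1.9 to 2.7.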

Compound 4, distribution coefficient: 2.2
Compound 4: middle estimate off by 0.10 log units, on the high side; measured number inside the range.
By their numbers in this assay, from the lowest: compound 3; then compounds 1, 4 and 2 (each within the scatter of the next).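

In this assay, bromo in place of 3-methylpyridin-2-yl on an aromatic carbon, para to a large group, gives a number 0.20 log units higher from compound 1 to compound 4 (within the scatter), so at this place a single bromine and a seven-atom aromatic ring read alike, at least on this core with this chain. Amino in place of hydroxy on a carbonyl carbon gives a number 0.60 log units higher from compound 3 to compound 4 (beyond the scatter), which isolates that exchange at a single configuration as drawn and places it beyond the scatter, whereas the earlier step, a number 0.70 log units lower from compound 2 to compound 3 (beyond the scatter), also crossed the stereocentre. The opposite configuration at the saturated chain carbon gives a number 0.10 log units lower from compound 2 to compound 4 (within the scatter), and that step reads on the stereocentre alone: the fact that compounds 2 and 4 differ only in the configuration as drawn.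

Only bromo and 3-methylpyridin-2-yl are shown at this place, so it remains open whether an amine-bearing ring, a morpholine or a plain phenyl would also stay within the scatter of them. On these data alone, it also remains open whether the exchange of carbonyl amino for hydroxy keeps its size alongside 3-methylpyridin-2-yl, and whether a longer chain in place of 1-carbamoylpropyl moves the number.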